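Working notes: a further acetyl on the aromatic oxygen

The source may hold more compounds than are shown below. What is called first, only, known or untested is meant among the compounds shown, and "the series" means these compounds.

Measured so far:
compound 1, `CC(=O)Oc1cc(O)c2c(=O)c(-c3ccc(O)cc3)coc2c1`: in a functional assay on HT-29 cells (Homo sapiens) for inhibition, read by MTT assay (a higher number here means a weaker inhibitor of growth, a lower number a stronger inhibitor of growth), compound 1 gives 4.21 uM
compound 2, `CCCCCCCCOc1ccc(-c2coc3cc(OCCCCCCCC)cc(O)c3c2=O)cc1`: in this assay compound 2 gives 10.8 uM

Compound 1 has the lower of the two numbers; compound 2 sits higher, and the gap between them lies beyond the usual scatter. The two differ in several places at once, so nothing can be read from that pair about any single change.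

Compound 3, `CC(=O)Oc1ccc(-c2coc3cc(OC(C)=O)cc(O)c3c2=O)cc1`, has not yet been measured in this assay. It follows from compound 1 by one change: acetyl in place of hydrogen on an oxygen on an aromatic ring. Compound 1 already carries one acetoxy group on its core, and the change adds a second cap of the same kind to the pendant aromatic ring. Among the measured compounds shown here, with no measured pair isolating this change, the expected step of a 1.3-fold higher number from compound 1 to compound 3 (0.12 log units; within the scatter) is small, most likely within the scatter, with a slight lean toward a higher number. Compound 3 is thus expected to give 5.5 uM, in a range of 2.2 uM to 14 uM.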

Compound 3, concentration for growth inhibition (reported as GI): 19.4 uM
Estimate against measurement, compound 3: 3.5-fold (0.55 log units) below; measured number outside the range, above it.
By their numbers in this assay, from the lowest: compound 1; then compounds 2 and 3 (each within the scatter of the next).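

This gives the series its first pair that differs in one place: in this assay, acetyl in place of hydrogen on an oxygen on an aromatic ring produces a 4.6-fold higher number from compound 1 to compound 3 (0.66 log units; beyond the scatter), so this hydroxy to acetoxy change moves toward weaker inhibition of growth. Capping this oxygen is therefore not neutral in this pair, even though compound 1 already carries an acetoxy group elsewhere and still has the lowest number of the series. Nothing measured here accounts for the step.

From the compounds shown here alone, whether the same oxygen behaves alike with a methyl ether or a longer acyl chain in place of acetyl remains open. Also open, going by these compounds, is whether the step would hold if the other acetoxy group were returned to hydroxy.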